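The source may report more compounds than this note shows. Statements on the series, on what has been measured and on what is new or still open speak of the compounds shown alone.

In an assay on HEK293 cells for agonist activity at transient receptor potential cation channel subfamily M member 8 (Homo sapiens), read by fluorescence and calcium flux, with a stated time of 15 min (on this read-out higher numbers stand for an effect only at larger amounts of compound and lower numbers for an effect already at smaller amounts), compound 1 `Cc1ccc(OCC(=O)N(Cc2cccs2)C2CC2)cc1` gives 8 nM and compound 3 `CON(Cc1cccs1)C(=O)COc1ccc(C)cc1` gives 10 nM, the second highest of the three numbers shown, while compound 2 `Cc1ccc(OCC(=O)N(Cc2cccs2)c2ccn(C)n2)cc1` gives 855 nM. The steps between them are a 1.3-fold higher number from compound 1 to compound 3 (0.10 log units; within the scatter) and a 110-fold higher number from compound 1 to compound 2 (2.03 log units; beyond the scatter). Compound 4 `CCCN(Cc1cccs1)C(=O)COc1ccc(C)cc1` differs from compound 3 by propyl in place of methoxy on an amide-type nitrogen. The step that bears on this change is a 1.3-fold higher number from compound 1 to compound 3 (0.10 log units; within the scatter), in which methoxy and cyclopropyl on the amide-type nitrogen gave numbers within the scatter of each other, whereas the large step of a 110-fold higher number from compound 1 to compound 2 (2.03 log units; beyond the scatter) came only when 1-methyl-1H-pyrazol-3-yl entered. Propyl is taken as nearer the former case, so no step beyond the scatter is expected in this assay, namely a 1.2-fold higher number from compound 3 to compound 4 (0.08 log units; within the scatter). Compound 4 is therefore estimated at 12 nM, within a range from 4 nM to 40 nM.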

Compound 4, half-maximal effective concentration: 40 nM
For compound 4 the middle estimate is 3.3-fold (0.52 log units) below the measured one, and the stated range covers the measured number.
By their numbers in this assay, from the lowest: compounds 1 and 3 (each within the scatter of the next); then compound 4; then compound 2.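

On the amide-type nitrogen in this assay the match of methoxy and cyclopropyl does not extend to propyl, which brings a 4.0-fold higher number from compound 3 to compound 4 (0.60 log units; beyond the scatter) and also a 5.0-fold higher number from compound 1 to compound 4 (0.70 log units; beyond the scatter) at this place. Propyl still lies far from 1-methyl-1H-pyrazol-3-yl, with a 21-fold lower number from compound 2 to compound 4 (1.33 log units; beyond the scatter) on that change. Nothing measured here explains these differences. On these data alone, it remains open whether ethyl or a longer chain such as butyl would follow propyl or stay with methoxy and cyclopropyl. Also open, as far as these compounds go, is where an amine or a carboxylic acid at the end of such a chain would fall.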